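The compounds below may be only part of what the source reports. "The series", "measured", "known", "first", "only" and "open" are said of these compounds alone.

Series notes. Compound 1, `O=S(=O)(Nc1ccccn1)c1ccc(Nc2nncc3ccccc23)cc1`, and compound 2, `Cc1cc(C)nc(NS(=O)(=O)c2ccc(Nc3nncc4ccccc34)cc2)n1`, share one core and differ only in the group on the sulfonamide nitrogen. In a functional assay on DU-145 cells (Homo sapiens) for antiproliferative activity, read by sulforhodamine B assay, with a stated time of 72 h (a higher number here means a weaker inhibitor, a lower number a stronger inhibitor), compound 1 gives 54 nM; compound 2 gives 7.8 nM in this assay. The step of a 6.9-fold lower number from compound 1 to compound 2 (0.84 log units; beyond the scatter) separates them clearly. Among the two numbers so far compound 2 stands lowest, with compound 1 as its only and nearest neighbour.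

Compound 3, `NS(=O)(=O)c1ccc(Nc2nncc3ccccc23)cc1`, is the next case: hydrogen in place of 4,6-dimethylpyrimidin-2-yl on a sulfonamide nitrogen. A single measured step bears on it, a 6.9-fold lower number from compound 1 to compound 2 (0.84 log units; beyond the scatter), and it shows that exchanging one group for another on that nitrogen moves the number well beyond the scatter. Within the data shown here, no measured compound carries only hydrogen there, so the data do not fix the direction of removing the group altogether. Among the measured compounds shown here, since the one exchange of groups had a clear effect, the number is taken to depend on what sits on that nitrogen, and for compound 3 a rise in this assay of moderate size, with wide uncertainty, is expected. The expected step is a 13-fold higher number from compound 2 to compound 3 (1.11 log units; beyond the scatter). Compound 3 is therefore estimated at 100 nM, within 20 nM to 600 nM.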

Compound 3, half-maximal inhibitory concentration: 14 nM
Compound 3: the middle estimate sits 7.1-fold (0.85 log units) above what was measured; measured number outside the range, below it.
By their numbers in this assay, from the lowest: compounds 2 and 3 (each within the scatter of the next); then compound 1.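

Taking the whole 4,6-dimethylpyrimidin-2-yl group off the sulfonamide nitrogen leaves the number in this assay within the scatter (a 1.8-fold higher number from compound 2 to compound 3 (0.25 log units; within the scatter)), so a group of that size on this nitrogen is not needed for a low number, and compound 2 and compound 3 cannot be separated here. Hydrogen in place of pyridin-2-yl at the same nitrogen does give a separation beyond the scatter, though a modest one (a 3.9-fold lower number from compound 1 to compound 3 (0.59 log units; beyond the scatter)), which leaves compound 1 with the highest number of the three and recasts the earlier exchange of groups: among these compounds, it is pyridin-2-yl that stands apart, while hydrogen and 4,6-dimethylpyrimidin-2-yl read alike. Nothing available bears on why the three compounds fall as they do.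

The compounds shown leave open how other groups on the sulfonamide nitrogen would read, such as a methyl, an acetyl or a phenyl ring, and whether pyridin-2-yl is alone in standing apart. They also leave open whether pyrimidin-2-yl without its two methyl groups would read with compound 2 or with compound 1.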